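Pyrazolyl urea series: aryl versus methyl on the ring nitrogen

The source may report more compounds than this note shows. Statements on the series, on what has been measured and on what is new or still open speak of the compounds shown alone.

Of the compounds shown here, two of the shared core have been measured in an assay on isolated protein for inhibition of Ephrin type-A receptor 2 (Homo sapiens), read by thermal shift assay, tested at 10 uM; a lower number here means that the compound stabilises the target less, a higher number that the compound stabilises the target more against heat. Among the measured compounds shown here, compound 1 `CC(C)(C)c1cc(NC(=O)Nc2cc(C(F)(F)F)cc(C(F)(F)F)c2)n(-c2ccccc2)n1` gives 0.8 degrees C, and compound 2 `Cn1nc(C(C)(C)C)cc1NC(=O)Nc1cc(C(F)(F)F)cc(C(F)(F)F)c1` gives 0.4 degrees C. Compound 2 thus stands beside compound 1, the two numbers inseparable within the scatter; the step of a number 0.40 degrees C lower from compound 1 to compound 2 (within the scatter) is the only step measured so far.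

Compound 3 `CC(C)(C)c1cc(NC(=O)Nc2cc(C(F)(F)F)cc(C(F)(F)F)c2)n(-c2ccc(F)cc2)n1` is not yet measured. It differs from compound 2 by 4-fluorophenyl in place of methyl on an aromatic nitrogen. For the measured compounds named here, the one measured step bears directly on this change, since it runs in the opposite direction: replacing phenyl by methyl gave a number 0.40 degrees C lower from compound 1 to compound 2 (within the scatter), within the scatter. Putting an aryl group back, here 4-fluorophenyl, is therefore expected to give no step beyond the scatter, with compound 3 expected to land close to compound 1, the step of a number 0.40 degrees C higher from compound 2 to compound 3 (within the scatter) being the estimate. Compound 3 is estimated at 0.8 degrees C, with a range from -0.2 degrees C to 1.8 degrees C.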

Compound 3, shift of the target's melting temperature: 0.4 degrees C
The estimate for compound 3 lay 0.40 degrees C above the measured number; measured number inside the range.
By their numbers in this assay, from the lowest: compounds 2, 3 and 1 (each within the scatter of the next).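

In this assay the aromatic nitrogen now carries a third group, and 4-fluorophenyl in place of methyl gives no change at the digits printed from compound 2 to compound 3 (within the scatter) and so does not separate a six-membered aromatic ring from a single methyl at this position. Fluoro in place of hydrogen on an aromatic carbon gives a number 0.40 degrees C lower from compound 1 to compound 3 (within the scatter) and so adds no step beyond the scatter to the aryl group either. No supporting measurement accompanies these numbers.

Only methyl, phenyl and 4-fluorophenyl are shown on this nitrogen, so whether an amine, a carboxylic acid or a longer alkyl chain there would give a step beyond the scatter remains open. The tert-butyl group and the two trifluoromethyl groups are the same in all three compounds, so what they contribute to these numbers cannot be read.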